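Trimming an Isopropyl to Ethyl in a Reductase Inhibitor Series

This account rests on a few compounds, and the source may have more. Where it says the series, first, only, none or still open, it means among the compounds named here.

Of the compounds shown here, three sharing one core have been measured in an assay on microsomes from liver for inhibition of 3-hydroxy-3-methylglutaryl-coenzyme A reductase (Rattus norvegicus), read by scintillation counting, with stated times of 0.5 h and 0.75 h; a higher number here means a weaker inhibitor, a lower number a stronger inhibitor. Compound 1 `CC(C)c1c(C(=O)NCc2ccccc2)nc(-c2ccc(F)cc2)n1CC[C@@H](O)C[C@@H](O)CC(=O)O` gives 7.9 nM. Compound 2 `O=C(O)C[C@H](O)C[C@H](O)CCn1c(-c2ccc(F)cc2)nc(C(=O)NCc2ccccc2F)c1C1CC1` gives 1.5 nM, and compound 3 `COc1cccc(CNC(=O)c2nc(-c3ccc(F)cc3)n(CC[C@@H](O)C[C@@H](O)CC(=O)O)c2C2CC2)c1` gives 1.2 nM. Among these three, compound 1 has the highest number and is therefore the weakest inhibitor of the set; compound 2 is nearest to it and compound 3 furthest, with both gaps beyond the scatter. For the measured compounds named here, the only measured step that changes a single place, a 1.3-fold lower number from compound 2 to compound 3 (0.10 log units; within the scatter), concerns the aryl group on the amide side and lies within the scatter.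

Compound 4 `CCc1c(C(=O)NCc2ccccc2)nc(-c2ccc(F)cc2)n1CC[C@@H](O)C[C@@H](O)CC(=O)O` has not yet been measured. It differs from compound 1 as follows: hydrogen in place of methyl on a saturated chain carbon bound to an aromatic carbon and a saturated chain carbon. Going by the values given here, no measured step touches this part of the molecule: compounds 2 and 3 differ from compound 1 in more than one place, so their values show only that several changes together give lower numbers. Among the compounds with values here, with no direct precedent in the data, the step of a 1.5-fold higher number from compound 1 to compound 4 (0.18 log units; within the scatter) is expected to be small, leaning slightly toward a higher number but not clearly beyond the scatter. The estimated value for compound 4 in this assay is 12 nM, with a range from 4 nM to 40 nM.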

Compound 4, half-maximal inhibitory concentration: 123 nM
The estimate for compound 4 lay 10-fold (1.01 log units) below the measured number, and the stated range ends below it.
By their numbers in this assay, from the lowest: compounds 3 and 2 (each within the scatter of the next); then compound 1; then compound 4.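

Cutting the isopropyl group down to ethyl, a loss of one methyl that adds no ring and no hydrogen-bond donor or acceptor, gives a 16-fold higher number from compound 1 to compound 4 (1.19 log units; beyond the scatter) in this assay. For the compounds shown here, this is the first reading of this place on its own, since the earlier compounds differed from compound 1 in more than one place, and it shows that a single carbon here can separate a clearly stronger inhibitor from a clearly weaker one. Nothing available on this pair offers an explanation for the size of the step.

Only isopropyl and ethyl can be compared directly, so this one step cannot show how the number would respond to a methyl, a longer chain such as propyl, or a more branched group such as tert-butyl at the same place. Compounds 2 and 3 carry a cyclopropyl group instead of isopropyl but also differ from compound 1 on the amide side, which leaves the contribution of the cyclopropyl group alone unresolved.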